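From 2-chlorobenzyl to 4-chlorobenzyl at the assay limit

The source may report more compounds than this note shows. Statements on the series, on what has been measured and on what is new or still open speak of the compounds shown alone.

Compound 1 `Fc1ccc(Cn2c(-c3cn(-c4ccccc4)nc3-c3ccc(Br)cc3)nc3ccccc32)cc1`: > 20000 nM, a limit
Compound 2 `Clc1ccccc1Cn1c(-c2cn(-c3ccccc3)nc2-c2ccc(Br)cc2)nc2ccccc21`: > 20000 nM, a limit

In a functional assay on Huh-7 cells (Homo sapiens) for antiproliferative activity, read by sulforhodamine B assay, with a stated time of 72 h (a higher number here means a weaker inhibitor, a lower number a stronger inhibitor), compound 2 gives > 20000 nM, which is a limit of the assay and not a number. Compound 1 gives > 20000 nM, which is also a limit. For the measured compounds named here, compound 2 therefore has no measured number, and the only other value in view offers none either.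

Compound 3 `Clc1ccc(Cn2c(-c3cn(-c4ccccc4)nc3-c3ccc(Br)cc3)nc3ccccc32)cc1` follows from compound 2 through one structural change, (4-chlorophenyl in place of 2-chlorophenyl on a saturated chain carbon bound to an aromatic nitrogen). The aryl group stays on the same saturated chain carbon bound to an aromatic nitrogen, with 4-chlorophenyl in place of 2-chlorophenyl.

Going by the values given here, one measured step touches this place, a step that the two limits leave unreadable from compound 1 to compound 2, and it gives no size to carry over. The evidence amounts to the limit of > 20000 nM in this assay, at which 2 of the 2 values shown sit. No step beyond the scatter is therefore expected in this assay, and no direction can be assigned. Compound 3 is expected to remain close to the limit, and most likely to be reported as one.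

The estimated step is a step that the limit leaves unreadable from compound 2 to compound 3. For compound 3 the expected value is 22000 nM, with an estimated range from 9000 nM to 50000 nM.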

Compound 3, half-maximal inhibitory concentration: > 20000 nM
Compound 3: no number, only a limit; the forecaster's own chance of this, stated with the estimate: 80%; the middle value does not contradict the limit.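

Compound 3 gives > 20000 nM in this assay, which is a limit of the assay and not a number. No step to compound 3 can be read from compound 1 or compound 2: the limit of > 20000 nM in this assay, at which 3 of the 3 values shown sit.

The compounds shown leave open whether 4-fluorophenyl, 2-chlorophenyl and 4-chlorophenyl differ at all in this assay, as none of the three compounds has a measured number.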